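The source may hold more compounds than are shown below. What is called first, only, known or untested is meant among the compounds shown, and "the series" means these compounds.

Compound 1 `CC(=O)Nc1ccc(NC(=O)NCCCCC(c2ccc(F)cc2)c2ccc(F)cc2)cc1` opens the set. In a functional assay on MDA-MB-231 cells (Homo sapiens) for cytotoxicity, read by MTT assay, with a stated time of 48 h (a higher number here means a weaker inhibitor, a lower number a stronger inhibitor), compound 1 reached only a limit, > 20000 nM, and not a number. Going by the values given here, compound 2 `O=C(NCCCCC(c1ccc(F)cc1)c1ccc(F)cc1)Nc1ccc(Cl)c([N+](=O)[O-])c1` is the one member of the set with a number: in this assay compound 2 gives 4060 nM. Among the compounds with values here, the step of an at least 4.9-fold lower number from compound 1 to compound 2 (0.69 log units; beyond the scatter) is the sole measured step, and on one side it rests on (the limit of > 20000 nM in this assay, at which 1 of the 2 values shown sits). Compound 3 `O=C(NCCCCC(c1ccc(F)cc1)c1ccc(F)cc1)c1ccc(Cl)c(C(F)(F)F)c1` is not yet measured; it differs from compound 2 as 4-chloro-3-(trifluoromethyl)phenyl in place of (4-chloro-3-nitrophenyl)amino on a carbonyl carbon. The measured step changed only the aryl group on the amide-type nitrogen and kept the rest of the shared core, so it does not speak to trading the (4-chloro-3-nitrophenyl)amino group for 4-chloro-3-(trifluoromethyl)phenyl on the carbonyl carbon; no shown step bears on this change. Compound 3 is therefore expected to stay within the scatter of compound 2, with the estimated step of a 1.0-fold lower number from compound 2 to compound 3 (0.01 log units; within the scatter). Compound 3 is estimated at 4000 nM, between 1300 nM and 13000 nM.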

Compound 3, half-maximal inhibitory concentration: 11700 nM
For compound 3 the middle estimate is 2.9-fold (0.47 log units) below the measured one; the measured number falls inside the stated range.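

With the nitrogen-linked aryl group replaced by a directly attached one on the carbonyl carbon, this assay shows a 2.9-fold higher number from compound 2 to compound 3 (0.46 log units; beyond the scatter), so this position responds to a change that the earlier step, which kept the amide-type nitrogen, could not test. The change removes the hydrogen-bond donor and acceptors counted on the leaving group, but it also exchanges nitro for trifluoromethyl, and the data do not separate the two. The comparison with the other end of the set shows an at least 1.7-fold lower number from compound 1 to compound 3 (0.23 log units; that floor lies within the scatter), which sets no firm order, as its floor lies within the scatter and rests on a limit: the limit of > 20000 nM in this assay, at which 1 of the 3 values shown sits.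

Still open, as far as these compounds go, is whether a (4-chloro-3-(trifluoromethyl)phenyl)amino group would keep the number of compound 2, or a 4-chloro-3-nitrophenyl group on the carbonyl carbon that of compound 3. Nor do the compounds shown tell how a longer chain in place of the butyl linker would fare.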